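Shortening the Alkynyl Chain on a Shared Nucleoside Core

The source may hold more compounds than are shown below. What is called first, only, known or untested is meant among the compounds shown, and "the series" means these compounds.

Measured so far:
Compound 1, `C=C[C@@]1(O)[C@@H](CO)O[C@@H](n2ccc(=O)[nH]c2=O)[C@@H]1O`: in a functional assay on L1210 cells (Mus musculus), read by MTT assay (on this read-out higher numbers stand for weaker inhibition and lower numbers for stronger inhibition), compound 1 gives 148000 nM.
Compound 2, `CCC#C[C@@]1(O)[C@@H](CO)O[C@@H](n2ccc(=O)[nH]c2=O)[C@@H]1O`: in this assay compound 2 gives 338000 nM.

Both compounds share one core and differ only in the group on a saturated ring carbon. Among the measured compounds shown here, compound 2 stands at the higher of the two numbers in this assay, so it is the weaker inhibitor of the pair; the only measured step, a 2.3-fold higher number from compound 1 to compound 2 (0.36 log units; beyond the scatter), comes with but-1-yn-1-yl in place of vinyl on a saturated ring carbon.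

Compound 3, `CC#C[C@@]1(O)[C@@H](CO)O[C@@H](n2ccc(=O)[nH]c2=O)[C@@H]1O`, has not yet been measured. It differs from compound 2 by hydrogen in place of methyl on a saturated chain carbon bound to a triple-bonded carbon; read one bond further out, this is but-1-yn-1-yl to prop-1-yn-1-yl. For the measured compounds named here, the one step available, a 2.3-fold higher number from compound 1 to compound 2 (0.36 log units; beyond the scatter), went with a longer substituent and a higher number, so trimming the chain back toward the size of compound 1 might pull the number down somewhat, but it is a different kind of change and a small step that stays within the scatter is just as plausible. For compound 3 in this assay the expected value is 250000 nM, with a range from 100000 nM to 600000 nM. This estimate amounts to an expected step of a 1.4-fold lower number from compound 2 to compound 3 (0.13 log units; within the scatter).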

Compound 3, half-maximal inhibitory concentration: 354000 nM
Compound 3: middle estimate off by 1.4-fold (0.15 log units), on the low side, within the range that was stated.
By their numbers in this assay, from the lowest: compound 1; then compounds 2 and 3 (each within the scatter of the next).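

In this assay, but-1-yn-1-yl and prop-1-yn-1-yl on the shared core give a 1.0-fold higher number from compound 2 to compound 3 (0.02 log units; within the scatter) and so cannot be told apart at this position: hydrogen in place of methyl on a saturated chain carbon bound to a triple-bonded carbon makes no difference that this read-out can resolve. The gap to the vinyl compound holds with the shorter chain too, since the shorter chain comes with a 2.4-fold higher number from compound 1 to compound 3 (0.38 log units; beyond the scatter) and the longer chain came with a 2.3-fold higher number from compound 1 to compound 2 (0.36 log units; beyond the scatter) in the same way, so among these three compounds the gap does not depend on which of the two alkynyl chains is present. Nothing available bears on what lies behind these numbers.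

The compounds shown leave open whether the bare ethynyl group, a longer chain such as hex-1-yn-1-yl, or an alkynyl chain ending in an amine would stay level with compound 2 and compound 3 or move away from them. They also leave open whether the same picture would appear in any other cell line or assay.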